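Acetoxy in place of nitro on compound 2

A few compounds are considered here, and "the series" means these few. Any claim that something is new, unique, unknown or untested is made for them only; others in the source may bear on it.

In a functional assay on L1210 cells (Mus musculus) for antiproliferative activity, read by MTT assay, with a stated time of 72 h (a higher number here means a weaker inhibitor, a lower number a stronger inhibitor), compound 1 `COc1ccc(C2=NN(C(C)=O)C(c3cccc([N+](=O)[O-])c3)O2)cc1` gives 47000 nM. Compound 2 `COc1ccc(C2=NN(C(C)=O)C(c3ccc(OC)c([N+](=O)[O-])c3)O2)cc1` gives > 100000 nM, which is a limit of the assay and not a number. Compound 3 `COc1ccc(C2=NN(C(C)=O)C(c3ccc(OC)c(OC(C)=O)c3)O2)cc1` has acetoxy in place of nitro on an aromatic carbon, ortho to a methoxy group (acetoxy in place of nitro on an aromatic carbon). Among the compounds with values here, the only measured step is an at least 2.1-fold higher number from compound 1 to compound 2 (0.32 log units; beyond the scatter), at least modest, for methoxy in place of hydrogen. Within the data shown here, compound 3 retains that methoxy, and no measured step covers replacement of nitro, so the size of this change remains poorly defined. A reported number for compound 3 could only lie lower than the limit, and a further limit remains possible. The estimated step is an at least 2.2-fold lower number from compound 2 to compound 3 (0.34 log units; beyond the scatter), toward a lower number in this assay. For compound 3 the expected value is 45000 nM, with an estimated range of 10000 nM to 100000 nM.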

Compound 3, half-maximal inhibitory concentration: > 100000 nM
Compound 3: a limit, no number (the forecaster's own chance of this, stated with the estimate: 40%); middle value at least 2.2-fold (0.34 log units) from the limit.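

In this assay compound 3 gives > 100000 nM, a limit of the assay and not a number. Compound 2 also carries a limit, so no step between compound 2 and compound 3 can be read: the limit of > 100000 nM in this assay, at which 2 of the 3 values shown sit.

The compounds shown leave open whether acetoxy in place of nitro on an aromatic carbon shifts the number in this assay at all.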